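The source may report more compounds than this note shows. Statements on the series, on what has been measured and on what is new or still open speak of the compounds shown alone.

Working notes on the series. Compound 1 `COc1ccc2c(c1)C(NC(=O)CCCN1CCN(c3ccccc3OC)CC1)CCC2` gives 129 nM in an assay on HEK293 cells for displacement of a labelled ligand from 5-hydroxytryptamine receptor 7 (Rattus norvegicus); a lower number here means a stronger inhibitor, a higher number a weaker inhibitor. Compound 2 `O=C(CCCCCN1CCN(c2noc3ccccc23)CC1)NC1CCCc2ccccc21` gives 125 nM in this assay, and compound 3 `COc1ccc2oc(N3CCN(CCCCCC(=O)NC4CCCc5ccccc54)CC3)nc2c1` gives 704 nM. For the measured compounds named here, compound 3 thus carries the highest number of the three; compound 1 and compound 2 both sit well below it, and the one measured step at the ring nitrogen, a 5.6-fold higher number from compound 2 to compound 3 (0.75 log units; beyond the scatter), shows that swapping one bicyclic group for another on that position moves the number noticeably.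

The next change is 4-cyanophenyl in place of 5-methoxy-1,3-benzoxazol-2-yl on an amine nitrogen in a ring, giving compound 4 `N#Cc1ccc(N2CCN(CCCCCC(=O)NC3CCCc4ccccc43)CC2)cc1`. Going by the values given here, only the step from compound 2 to compound 3 bears directly on this position, and it was modest but beyond the scatter. The entering group is a single six-membered aromatic ring of carbon only, which puts compound 4 closer in kind to compound 1 at 129 nM than to the bicyclic groups of compound 2 and compound 3, though the chain length of compound 1 differs. On that basis a lower number than compound 3 is expected, roughly of the size seen in a 5.6-fold higher number from compound 2 to compound 3 (0.75 log units; beyond the scatter) but reversed, as the estimated step of a 3.2-fold lower number from compound 3 to compound 4 (0.51 log units; beyond the scatter). For compound 4 the expected value in this assay is 220 nM, with a likely range from 70 nM to 700 nM.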

Compound 4, inhibition constant: 1400 nM
Estimate against measurement, compound 4: 6.4-fold (0.80 log units) below; measured number outside the range, above it.
By their numbers in this assay, from the lowest: compounds 2 and 1 (each within the scatter of the next); then compounds 3 and 4 (each within the scatter of the next).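

At the amine nitrogen in a ring, 4-cyanophenyl and 5-methoxy-1,3-benzoxazol-2-yl do not separate in this assay, with a 2.0-fold higher number from compound 3 to compound 4 (0.30 log units; within the scatter); on these two compounds, leaving the five-membered aromatic ring and the methoxy group behind gives no measurable change. The group of compound 2 now stands apart from both of these groups, since the second comparison at this position gives an 11-fold higher number from compound 2 to compound 4 (1.05 log units; beyond the scatter), so the one-ring group does not come close to compound 2 even though compound 2 also has a bicyclic group, and the bicyclic groups of compound 2 and compound 3 do not behave alike. Nothing among the data shown accounts for this pattern.

Still open, from the compounds shown here alone, is whether the nitrile itself matters at this position, which a plain phenyl ring or a 4-methoxyphenyl group on the same chain and core would help to settle. Going by these compounds, compound 1 differs from these compounds in more than one place, so it remains open how a 2-methoxyphenyl group would read on the chain of compound 2.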